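A few compounds are considered here, and "the series" means these few. Any claim that something is new, unique, unknown or untested is made for them only; others in the source may bear on it.

Measured compounds:
compound 1, `NCC(O)Cn1c(=O)n(C2OC(CO)[C@@H](O)[C@H]2O)c2nc(N)nc(O)c21`, 110%
compound 2, `C=CCn1c(=O)n(C2C=CC(CO)O2)c2nc(N)nc(O)c21`, 45%
compound 3, `C=CCn1c(=O)n(CCC(CCOCc2ccccc2)CCOCc2ccccc2)c2nc(N)nc(O)c21`, 68%

In a functional assay on the whole organism (B cells) with Mus musculus as the target (a higher number here means a larger maximal response, a lower number a smaller maximal response), compound 1 gives 110%, the highest of the three values. Compound 3 gives 68%, a value that lies beyond the scatter from it, and compound 2 gives 45%, further away still. Among the measured compounds shown here, no two of these measured compounds differ in a single place, so no step between measured compounds can be read off. Compound 4, `Nc1nc(O)c2c(n1)n(C1OC(CO)[C@@H](O)[C@H]1O)c(=O)n2Cc1ccc(Cl)cc1`, differs from compound 1 in one place: 4-chlorophenyl in place of 2-amino-1-hydroxyethyl on a saturated chain carbon bound to an aromatic nitrogen. For the measured compounds named here, with no measured step of this kind to lean on, the expectation rests only on the spread of the three values. In this assay the expected step is a moderate decrease, a number 35 percentage points lower from compound 1 to compound 4 (beyond the scatter). Compound 4 is expected to reach 75%, within 40% to 110%.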

Compound 4, largest response reached (reported as maximal response), in percent of the reference or control that the assay uses: 15%
Compound 4: middle estimate off by 60 percentage points, on the high side; measured number outside the range, below it.
By their numbers in this assay, from the lowest: compound 4; then compound 2; then compound 3; then compound 1.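

In this assay, among the compounds shown here, the change to 4-chlorophenyl in place of 2-amino-1-hydroxyethyl, on a saturated chain carbon bound to an aromatic nitrogen, brings a large fall, a number 95 percentage points lower from compound 1 to compound 4 (beyond the scatter), and this is the first single-place step that can be read. It shows that, on the core of compound 1, the response depends strongly on the group at this place. Nothing shown gives a reason for the fall.

Going by these compounds, the swap replaces the amine, the hydroxyl and the chain end together, so which of them matters stays open. An unsubstituted benzyl or a simple aminopropyl chain at this place would separate these parts.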